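The source may hold more compounds than are shown below. What is called first, only, known or untested is meant among the compounds shown, and "the series" means these compounds.

Measured in an assay on isolated protein for binding affinity to Gonadotropin-releasing hormone receptor (Homo sapiens); a lower number here means a stronger inhibitor, a higher number a weaker inhibitor:

compound 1, `Cc1cc2c(cc1Cc1ccc(C(=O)NCC3CCCCC3)o1)C(C)(C)CCC2(C)C`: 180 nM
compound 2, `Cc1cc2c(cc1Cc1ccc(C(=O)NC[C@H]3CC[C@H](C(N)=O)CC3)o1)C(C)(C)CCC2(C)C`: 13 nM
compound 3, `Cc1cc2c(cc1Cc1ccc(C(=O)NCC3CCC(CN)CC3)o1)C(C)(C)CCC2(C)C`: 42 nM

Compound 3 stands second of the three numbers in this assay: it is a 4.3-fold lower number from compound 1 to compound 3 (0.63 log units; beyond the scatter), and a 3.2-fold higher number from compound 2 to compound 3 (0.51 log units; beyond the scatter). The change to compound 4, `Cc1cc2c(cc1Cc1ccc(C(=O)NCC3CCC(CNC(=O)C(F)(F)F)CC3)o1)C(C)(C)CCC2(C)C`, is (trifluoromethyl)carbonyl in place of hydrogen on an amine nitrogen. Of the measured steps, two bear on the question indirectly. Going from compound 1 to compound 2, a 14-fold lower number from compound 1 to compound 2 (1.14 log units; beyond the scatter), and going from compound 1 to compound 3, a 4.3-fold lower number from compound 1 to compound 3 (0.63 log units; beyond the scatter), show that what sits on the saturated ring carbon matters for this assay, and compound 2 carries a carbonyl-bearing group, as compound 4 will. Within the data shown here, no measured step, however, covers capping the amine nitrogen itself, so the direction of the change from compound 3 to compound 4 cannot be read from the data. The expectation is therefore that compound 4 shows a step of a 1.1-fold higher number from compound 3 to compound 4 (0.03 log units; within the scatter) in this assay, which is a small step in either direction, possibly none beyond the scatter. Compound 4 is estimated at 45 nM, with a range from 12 nM to 170 nM.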

Compound 4, inhibition constant: 66 nM
Estimate against measurement, compound 4: 1.5-fold (0.17 log units) below; the range from low to high includes it.
By their numbers in this assay, from the lowest: compound 2; then compounds 3 and 4 (each within the scatter of the next); then compound 1.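

In this assay, placing (trifluoromethyl)carbonyl on the amine nitrogen gives a 1.6-fold higher number from compound 3 to compound 4 (0.20 log units; within the scatter), so among the compounds shown, a free amine hydrogen at this position is not needed to keep the number in the range of compound 3. The advantage over the unsubstituted saturated ring also persists, with a 2.7-fold lower number from compound 1 to compound 4 (0.44 log units; beyond the scatter), and all three substituted compounds, compound 2, compound 3 and compound 4, now show lower numbers than compound 1, with none going against this pattern within the set. No independent evidence is available to explain why the free and capped amine compounds read alike in this assay.

Going by these compounds, it remains open whether this tolerance extends to other groups on the same nitrogen, such as acetyl or methanesulfonyl, or to a carboxylic acid in place of the aminomethyl group. Compound 2 alone is drawn with defined stereochemistry on the saturated ring, so the contribution of that arrangement to the values of compound 3 and compound 4 also stays unresolved.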